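The source may report more compounds than this note shows. Statements on the series, on what has been measured and on what is new or still open speak of the compounds shown alone.

Compound 1 `[SeH]c1nc(NCc2ccccc2)c2ccccc2n1` in a functional assay on MCF7 cells (Homo sapiens) for cytotoxicity, read by MTT assay, with a stated time of 72 h (on this read-out higher numbers stand for lower toxicity in this test and lower numbers for higher toxicity in this test), gives > 100000 nM, which is a limit of the assay. Compound 2 `C[Se]c1nc(NCc2ccccc2)c2ccccc2n1` in this assay gives > 100000 nM, likewise a limit. Compound 2 thus stands at the limit of > 100000 nM in this assay, at which 2 of the 2 values shown sit. The step that the two limits leave unreadable from compound 1 to compound 2 cannot be sized. Compound 3 `CSc1nc(NCc2ccccc2)c2ccccc2n1` differs from compound 2 by a group of 2 heavy atoms (1 carbon, 1 sulfur; no ring) in place of a group of 2 heavy atoms (1 carbon, 1 selenium; no ring), on an aromatic carbon. No readable measured step bears on this change, so no shift beyond the scatter is expected in either direction. Compound 3 is expected to give 150000 nM in this assay, within 40000 nM to 600000 nM. The expected step is then a step that the limit leaves unreadable from compound 2 to compound 3.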

Compound 3, concentration lethal to 50% of the cells: > 100000 nM
Compound 3: no number, only a limit; the forecaster's own chance of this, stated with the estimate: 75%; the middle value is on the limit's open side.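

No step among compound 1, compound 2 and compound 3 can be read in this assay, since all three sit at a limit: the limit of > 100000 nM in this assay, at which 3 of the 3 values shown sit.

The compounds shown leave open whether either change on selenium or the exchange for methylsulfanyl alters toxicity at all.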